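The compounds below may be only part of what the source reports. "The series", "measured", "known", "first", "only" and "open" are said of these compounds alone.

Measured compounds:
compound 1 `O=C1/C(=N\NC(=S)Nc2ccc(Cl)cc2)c2cc(Br)ccc2N1Cc1ccc(F)cc1`: 196000 nM
compound 2 `Cc1ccc(CN2C(=O)/C(=N\NC(=S)Nc3ccc(Cl)cc3)c3cc(Br)ccc32)cc1`: 193000 nM

In a functional assay on L1210 cells (Mus musculus), with a stated time of 48 h (a lower number here means a stronger inhibitor, a higher number a weaker inhibitor), compound 1 gives 196000 nM and compound 2 gives 193000 nM; these two numbers lie within the scatter of each other, so neither compound can be set apart from the other. Compound 3 `O=C1/C(=N\NC(=S)Nc2ccc(Cl)cc2)c2cc(Br)ccc2N1Cc1ccc(Cl)cc1` carries chloro in place of methyl on an aromatic carbon. Among the compounds with values here, the only measured step that bears on this, a 1.0-fold lower number from compound 1 to compound 2 (0.01 log units; within the scatter), also swapped one small group for another on an aromatic carbon and left the number unchanged. A similar outcome is expected for compound 3, namely a 1.0-fold lower number from compound 2 to compound 3 (0.01 log units; within the scatter), with no shift beyond the scatter. Compound 3 is therefore estimated at 190000 nM, within a range from 90000 nM to 400000 nM.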

Compound 3, half-maximal inhibitory concentration: >= 500000 nM
Compound 3 was reported as a limit; the forecaster's own chance of this, stated with the estimate: 10%; at least 2.6-fold (0.42 log units) between middle value and limit.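

In this assay compound 3 stands only as a limit of the assay, not as a number: the limit of >= 500000 nM in this assay, at which 1 of the 3 values shown sits. Even so, the 4-chlorobenzyl group gives an at least 2.5-fold higher number from compound 2 to compound 3 (0.41 log units; beyond the scatter) and an at least 2.5-fold higher number from compound 1 to compound 3 (0.40 log units; beyond the scatter). This position on the ring therefore does respond to a single-atom swap, with chloro going with weaker inhibition than methyl or fluoro, which the earlier pair alone did not show.

As far as these compounds go, the true size of these steps stays open. So does whether an amine or a carboxylic acid in this place would bring the number down.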